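This account rests on a few compounds, and the source may have more. Where it says the series, first, only, none or still open, it means among the compounds named here.

In an ADME assay on microsomes from liver (Rattus norvegicus) for metabolic stability, using NADPH, with a stated time of 10 min (on this read-out lower numbers stand for a less stable compound and higher numbers for a more stable compound), two compounds have been measured so far:

- compound 1 (`NC(=O)NC/C=C\CN(C[C@H]1Cc2ncccc2CN1)[C@H]1CCCc2cccnc21`) gives 1% remaining
- compound 2 (`CN(CCCCN(C[C@H]1Cc2ncccc2CN1)[C@H]1CCCc2cccnc21)C1CCC(F)(F)CC1`) gives 8% remaining

These two values lie within the scatter of each other, so compound 2 does not stand apart from compound 1, and little of either remains at the end of the incubation. Compound 3 (`c1cnc2c(c1)CN[C@@H](CN(CCCCNC1COC1)[C@H]1CCCc3cccnc31)C2`) comes from compound 2 through a single change at a saturated chain carbon, four bonds along the chain from an amine nitrogen, where (oxetan-3-yl)amino enters: a group of 5 heavy atoms (3 carbon, 1 nitrogen, 1 oxygen; one four-membered non-aromatic ring with 1 hetero atom) in place of a group of 10 heavy atoms (7 carbon, 1 nitrogen, 2 fluorine; one six-membered non-aromatic ring of carbon only), on a saturated chain carbon, four bonds along the chain from an amine nitrogen and the rest of the structure stays the same.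

Within the data shown here, no measured pair differs in one place alone, so the data give no direct size for this change. Compound 1 with 1% and compound 2 with 8% end their chains in different groups and still stay within the scatter, so no large change is expected. The estimated change is a number 2 percentage points higher from compound 2 to compound 3 (within the scatter) and is expected to stay within the scatter, with a slight rise as the likelier direction. For compound 3 the expected value in this assay is 10% with an estimated range from 2% to 30% for the coming measurement.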

Compound 3, percent of the compound remaining: 27%
Compound 3: middle estimate off by 17 percentage points, on the low side; low and high end bracket the measured number.
By their numbers in this assay, from the lowest: compounds 1 and 2 (each within the scatter of the next); then compound 3.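

At this position the end of the chain does affect the read-out in this assay: with (oxetan-3-yl)amino in place of the larger carbocyclic group, the number is a number 19 percentage points higher from compound 2 to compound 3 (beyond the scatter), whereas the two earlier compounds, which also end their chains differently, stayed within the scatter of each other. The same end group also separates from the open-chain group of the first compound, with a number a number 26 percentage points higher from compound 1 to compound 3 (beyond the scatter), so two different one-place comparisons now point the same way, though compound 3, at 27%, still leaves most of the material gone after the incubation. No measurement on hand explains this rise, so the result stands as an observation only.

The single step changes the ring size, the ring oxygen and the hydrogen on the amine nitrogen together, so the compounds shown do not tell which of these carries the rise. As far as these compounds go, whether a cyclobutylamino or a tetrahydropyran-4-ylamino group would give a similar number, and whether the rise would hold on a longer chain, remains open.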